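Halogen to alkyl swap on the anilino ring

The compounds below may be only part of what the source reports. "The series", "measured", "known", "first", "only" and "open" are said of these compounds alone.

Compound 3 `COc1cc2ncnc(Nc3ccc(Br)cc3)c2cc1OCCCCC(=O)Nc1ccc(S(N)(=O)=O)cc1` is one of three analogues sharing the same core and side chain; in a functional assay on A-431 cells (Homo sapiens) for antiproliferative activity, read by MTT assay, with a stated time of 72 h (a higher number here means a weaker inhibitor, a lower number a stronger inhibitor), compound 3 gives 6570 nM. Among the three numbers it stands second highest: compound 1 `COc1cc2ncnc(Nc3ccc(Cl)c(C(F)(F)F)c3)c2cc1OCCCCC(=O)Nc1ccc(S(N)(=O)=O)cc1` gives 3910 nM, a gap that lies within the scatter, while compound 2 `COc1cc2ncnc(Nc3ccc(F)cc3)c2cc1OCCCCC(=O)Nc1ccc(S(N)(=O)=O)cc1` gives 18600 nM, with a 2.8-fold lower number from compound 2 to compound 3 (0.45 log units; beyond the scatter). The change to compound 4 `CCc1ccc(Nc2ncnc3cc(OC)c(OCCCCC(=O)Nc4ccc(S(N)(=O)=O)cc4)cc23)cc1` is ethyl in place of bromo on an aromatic carbon. The steps measured so far alter only halogens at this place or the whole ring: a 1.7-fold higher number from compound 1 to compound 3 (0.23 log units; within the scatter) and a 4.8-fold higher number from compound 1 to compound 2 (0.68 log units; beyond the scatter). Among the measured compounds shown here, no step yet exchanges a halogen for an alkyl group, so the measured steps bear on it only indirectly; the spread they show among para substituents is modest. The step of a 1.4-fold higher number from compound 3 to compound 4 (0.14 log units; within the scatter) is therefore expected to be small, most likely a somewhat higher number, with a real chance of no change beyond the scatter. For compound 4 the expected value is 9000 nM, in the range 3500 nM to 22000 nM.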

Compound 4, half-maximal inhibitory concentration: 7220 nM
Compound 4: the middle estimate sits 1.2-fold (0.10 log units) above what was measured, and the stated range covers the measured number.
By their numbers in this assay, from the lowest: compounds 1, 3 and 4 (each within the scatter of the next); then compound 2.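

In this assay, among the compounds shown here, the first alkyl group at this place, ethyl in place of bromo, gives a step inside the scatter (a 1.1-fold higher number from compound 3 to compound 4 (0.04 log units; within the scatter)), so at this position ethyl and bromo are not told apart. The same holds for 4-ethylphenyl against the more heavily substituted ring of compound 1 (a 1.8-fold higher number from compound 1 to compound 4 (0.27 log units; within the scatter)), while the fluoro analogue stays clearly separate (a 2.6-fold lower number from compound 2 to compound 4 (0.41 log units; beyond the scatter)), which leaves compound 2 as the only one of the four set apart from the rest. No measurement at hand accounts for these gaps.

Open, on these data alone, is whether a longer chain such as butyl at this place would stay with compounds 1, 3 and 4. For the compounds shown here, equally open is how an amine or a carboxylic acid there would read, since all substituents at this place so far carry no hydrogen-bond donors or acceptors.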